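This account rests on a few compounds, and the source may have more. Where it says the series, first, only, none or still open, it means among the compounds named here.

Measured compounds in an assay on isolated protein for inhibition of Ephrin type-A receptor 2 (Homo sapiens), read by thermal shift assay, tested at 10 uM; a lower number here means that the compound stabilises the target less, a higher number that the compound stabilises the target more against heat:
compound 1, `CC(C)(C)c1cc(NC(=O)Nc2cc(F)cc(F)c2)n(-c2ccccc2)n1`: 2.7 degrees C
compound 2, `Cn1nc(C(C)(C)C)cc1NC(=O)Nc1cc(F)cc(F)c1`: 0.4 degrees C
compound 3, `CC(C)(C)c1cc(NC(=O)Nc2cc(F)cc(F)c2)n(-c2ccc(F)cc2)n1`: 1.9 degrees C

Compound 3 stands second highest of the three numbers. Its nearest neighbour is compound 1, whose value lies a little higher, and that gap, a number 0.80 degrees C lower from compound 1 to compound 3 (within the scatter), stays within the scatter. Its furthest neighbour is compound 2, and the step of a number 1.5 degrees C higher from compound 2 to compound 3 (beyond the scatter) lies beyond the scatter.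

The next compound, compound 4, `CC(C)(C)c1cc(NC(=O)Nc2cc(F)cc(F)c2)n(C(C)(C)C)n1`, differs from compound 3 in one place: tert-butyl in place of 4-fluorophenyl on an aromatic nitrogen. Among the compounds with values here, two measured steps bear on a change at this aromatic nitrogen. When methyl replaced phenyl there, the step of a number 2.3 degrees C lower from compound 1 to compound 2 (beyond the scatter) was a modest loss; when 4-fluorophenyl replaced methyl, the step of a number 1.5 degrees C higher from compound 2 to compound 3 (beyond the scatter) was a modest gain. Both steps point the same way: a group without a ring at this nitrogen goes with a lower shift than a group with one. Within the data shown here, no measured step places tert-butyl at this nitrogen, so the size of the loss for tert-butyl rests on the methyl case only.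

Compound 4 is therefore expected to give 1 degrees C in this assay, with a range from 0 degrees C to 2.2 degrees C. The expected step from compound 3 is a number 0.90 degrees C lower from compound 3 to compound 4 (within the scatter), a modest loss.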

Compound 4, shift of the target's melting temperature: 0 degrees C
The estimate for compound 4 lay 1.0 degrees C above the measured number; measured number inside the range.
By their numbers in this assay, from the lowest: compounds 4 and 2 (each within the scatter of the next); then compounds 3 and 1 (each within the scatter of the next).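

The tert-butyl result extends the earlier picture from methyl to a second group without a ring: in this assay, the changes from the two aryl groups to tert-butyl give a number 1.9 degrees C lower from compound 3 to compound 4 (beyond the scatter) and a number 2.7 degrees C lower from compound 1 to compound 4 (beyond the scatter), both beyond the scatter. The step of a number 0.40 degrees C lower from compound 2 to compound 4 (within the scatter) stays within the scatter, so these numbers do not separate tert-butyl from methyl at this aromatic nitrogen, and enlarging a group without a ring brings no recovery of the shift here. Across these four compounds, the two bearing an aromatic ring on this nitrogen thus stand clear of the two bearing an alkyl group, with no compound going against that split, although no measurement shown accounts for it.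

The compounds shown leave open whether the ring must be aromatic, which a cyclohexyl group on this nitrogen would address, and whether it must sit directly on the nitrogen, which a benzyl group would address. They also leave open whether a pyridyl ring, or a phenyl ring carrying a methoxy group or a carboxylic acid, would keep the shift seen with the aryl groups.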